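The compounds below may be only part of what the source reports. "The series", "measured", "known", "first", "only" and "open" are said of these compounds alone.

Measured compounds:
compound 1 `O=C(CN1CN(c2ccccc2)C2(CCN(C(=O)c3ccc(C4CCCCC4)cc3)CC2)C1=O)N1CCC(CO)CC1` gives 1100 nM in an assay on HEK293 cells for displacement of a labelled ligand from NPC1-like intracellular cholesterol transporter 1 (Homo sapiens); on this read-out lower numbers stand for stronger inhibition and higher numbers for weaker inhibition;
compound 2 `CC1(C)CC(OC(=O)CN2CN(c3ccccc3)C3(CCN(C(=O)c4ccc(C5CCCCC5)cc4)CC3)C2=O)CC(C)(C)N1` gives 600 nM in this assay;
compound 3 `CS(=O)(=O)NCCNC(=O)CN1CN(c2ccccc2)C2(CCN(C(=O)c3ccc(C4CCCCC4)cc3)CC2)C1=O` gives 2100 nM in this assay.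

All three share one core and differ only in the group attached to the carbonyl carbon of the side chain. Compound 3 stands at the highest of the three numbers: against compound 1 the gap is a 1.9-fold higher number from compound 1 to compound 3 (0.28 log units; within the scatter), and against compound 2 it is a 3.5-fold higher number from compound 2 to compound 3 (0.54 log units; beyond the scatter).

Compound 4 `NCCNC(=O)CN1CN(c2ccccc2)C2(CCN(C(=O)c3ccc(C4CCCCC4)cc3)CC2)C1=O` keeps everything of compound 3 except one change: hydrogen in place of methylsulfonyl on an amine nitrogen. Going by the values given here, the measured steps all swap the whole group on the carbonyl carbon; none of them removes a methylsulfonyl from an amine nitrogen, so no measured step bears directly on this change. Among the compounds with values here, with no comparable step to lean on, the expected step of a 1.1-fold lower number from compound 3 to compound 4 (0.02 log units; within the scatter) from compound 3 to compound 4 is taken as none beyond the scatter. For compound 4 the estimate in this assay is therefore 2000 nM, with a range from 700 nM to 6000 nM.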

Compound 4, half-maximal inhibitory concentration: 3800 nM
Beside the measured number, compound 4's estimate is 1.9-fold (0.28 log units) below it, within the range that was stated.
By their numbers in this assay, from the lowest: compounds 2, 1, 3 and 4 (each within the scatter of the next, the first and the last beyond it).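

In this assay, going by these compounds alone, this is the first look at the amine nitrogen of the side chain itself, and taking the methylsulfonyl off leaves a step that cannot be told from the scatter (a 1.8-fold higher number from compound 3 to compound 4 (0.26 log units; within the scatter)). The 2-aminoethyl side chain does separate from the other two groups on the carbonyl carbon, with a step beyond the scatter from the 4-(hydroxymethyl)piperidin-1-yl group (a 3.5-fold higher number from compound 1 to compound 4 (0.54 log units; beyond the scatter)) and a larger one from the (2,2,6,6-tetramethylpiperidin-4-yl)oxy group (a 6.3-fold higher number from compound 2 to compound 4 (0.80 log units; beyond the scatter)), whereas the methylsulfonyl compound stayed within the scatter of the first of these. Nothing measured here accounts for these steps.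

Still open, from the compounds shown here alone, is what an acetyl or a methyl on that amine nitrogen would do. A longer chain between the amide nitrogen and the amine is equally untested by these compounds.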